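A few compounds are considered here, and "the series" means these few. Any claim that something is new, unique, unknown or untested is made for them only; others in the source may bear on it.

Compound 3 `c1csc(-c2ccccc2NCC2=NCCN2)c1` sits at the low end of the three numbers in a functional assay for activation of Alpha-1B adrenergic receptor (Homo sapiens), read by calcium flux; on this read-out higher numbers stand for an effect only at larger amounts of compound and lower numbers for an effect already at smaller amounts: compound 3 gives 5.75 nM. Compound 1 `c1coc(-c2ccccc2NCC2=NCCN2)c1` gives 6.31 nM, and the difference a 1.1-fold lower number from compound 1 to compound 3 (0.04 log units; within the scatter) is within the scatter. Compound 2 `Cc1nc(-c2ccccc2NCC2=NCCN2)cs1` gives 69.2 nM, and the step of a 12-fold lower number from compound 2 to compound 3 (1.08 log units; beyond the scatter) is large. Compound 4 `Cc1nc(-c2ccccc2NCC2=NCCN2)co1` is not yet measured; its change from compound 3 is 2-methyl-1,3-oxazol-4-yl in place of thiophen-2-yl on an aromatic carbon. Among the compounds with values here, two measured steps bear on it: the step of a 1.1-fold lower number from compound 1 to compound 3 (0.04 log units; within the scatter) lies within the scatter, whereas the step of an 11-fold higher number from compound 1 to compound 2 (1.04 log units; beyond the scatter) is large. The expected step is therefore a 10-fold higher number from compound 3 to compound 4 (1.02 log units; beyond the scatter), upward in this assay. Compound 4 is estimated at 60 nM, within a range from 20 nM to 180 nM.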

Compound 4, half-maximal effective concentration: < 5020 nM
Compound 4 ended at the assay's limit; the forecaster's own chance of this, stated with the estimate: 2%; the middle value does not contradict the limit.
By their numbers in this assay, from the lowest: compounds 3 and 1 (each within the scatter of the next); then compound 2.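

In this assay compound 4 gives < 5020 nM, which is a limit of the assay and not a number, so its steps from compounds 1, 2 and 3 cannot be read. The compounds shown leave open where compound 4 actually stands relative to those three.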